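The source may report more compounds than this note shows. Statements on the series, on what has been measured and on what is new or still open speak of the compounds shown alone.

Measured compounds: compound 1 `COc1cc(-c2cc(/C=C/C(=O)c3ccc(Cl)c(Cl)c3)[nH]n2)cc(OC)c1OC` with 72% and compound 2 `COc1ccc(-c2cc(/C=C/C(=O)c3cc(OC)c(OC)c(OC)c3)[nH]n2)cc1OC` with -25%.

Compound 1 was tested in a functional assay on Malme-3M cells (Homo sapiens) for cytotoxicity, read by sulforhodamine B assay, with a stated time of 48 h, tested at 10 uM (a lower number here means a stronger effect, a higher number a weaker effect of the compound at the concentration tested), and gave 72%; this is the higher of the two numbers shown. Compound 2 gave -25% in this assay, a number that lies far below that of compound 1, well beyond the scatter of the method. No single-change step between these two measured compounds is recorded, so their two values are simply shown side by side.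

Compound 3 `COc1cc(-c2cc(/C=C/C(=O)c3ccc(F)c(F)c3)[nH]n2)cc(OC)c1OC` has not yet been measured in this assay. It differs from compound 1 in one place: 3,4-difluorophenyl in place of 3,4-dichlorophenyl on a carbonyl carbon. Going by the values given here, nothing among the measured compounds tracks this kind of exchange, so the size of the step cannot be drawn from a measured pair. The expectation is a small shift toward a higher number, or none beyond the scatter; the step from compound 1 to compound 3 is estimated at a number 8 percentage points higher from compound 1 to compound 3 (within the scatter). For compound 3 the estimated value in this assay is 80%, with a range from 55% to 100%.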

Compound 3, a percentage reported as activity, at one concentration (the size of the read-out at that concentration, not a potency): -3%
Estimate against measurement, compound 3: 83 percentage points above; the whole stated range lies above it.
By their numbers in this assay, from the lowest: compound 2; then compound 3; then compound 1.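

In this assay, the place on a carbonyl carbon proves far from indifferent to which halogen the phenyl ring carries: 3,4-difluorophenyl in place of 3,4-dichlorophenyl gives a step (a number 75 percentage points lower from compound 1 to compound 3 (beyond the scatter)) that marks a much stronger effect at the concentration tested. The two groups match in everything counted here, with the same number of heavy atoms, the same six-membered aromatic ring of carbon only, no hydrogen-bond donors or acceptors and no net charge, so these counts do not separate a weak read-out from a strong one at this place. Nothing available explains why this exchange has so large an effect.

Going by these compounds alone, this single pair gives only one exchange at this place, so it leaves open how a 3,4-dibromophenyl, an unsubstituted phenyl, or a phenyl carrying a dimethylamino group or a carboxylic acid would read there. It also leaves open whether the exchange would bring a step of like size on a different core, and, as the read-out comes from one concentration, how the two compounds compare in potency.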